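A few compounds are considered here, and "the series" means these few. Any claim that something is new, unique, unknown or untested is made for them only; others in the source may bear on it.

Measured so far in a functional assay on A549 cells (Homo sapiens) for inhibition, read by sulforhodamine B assay, with a stated time of 48 h, tested at 50 uM; a lower number here means less inhibition of growth, a higher number more inhibition of growth at the concentration tested:
- Compound 1 `COc1ccc([C@@H]2C/C(=N/O)c3cc(CC=C(C)C)c(OC)cc3O2)cc1`: 66%
- Compound 2 `COc1ccc([C@@H]2C/C(=N/OCc3cn(-c4cccc(CO)c4)nn3)c3cc(CC=C(C)C)c(OC)cc3O2)cc1`: 43%
- Compound 3 `C#CCOc1ccc([C@@H]2CC(=O)c3cc(CC=C(C)C)c(OC)cc3O2)cc1`: 53%

Compound 2 lies within the scatter of compound 3, while compound 1 stands above compound 2 by more than the scatter. Compound 4 `COc1ccc([C@@H]2C/C(=N/OCc3cn(-c4cccnc4Cl)nn3)c3cc(CC=C(C)C)c(OC)cc3O2)cc1` has 2-chloropyridin-3-yl in place of the 3-(hydroxymethyl)phenyl of compound 2, on an aromatic nitrogen of a five-membered aromatic ring with 3 nitrogen (2-chloropyridin-3-yl in place of 3-(hydroxymethyl)phenyl on an aromatic nitrogen). Within the data shown here, no measured pair shows this change. Only compound 2, at 43%, carries this kind of substituted ring, so the expectation rests on that value, and no step beyond the scatter is expected in this assay. The expected change is a number 3 percentage points higher from compound 2 to compound 4 (within the scatter). For compound 4 the estimated value is 46%, with an expected range of 29% to 63%.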

Compound 4, percent growth inhibition at one concentration: 58%
Beside the measured number, compound 4's estimate is 12 percentage points below it; low and high end bracket the measured number.
By their numbers in this assay, from the lowest: compounds 2, 3, 4 and 1 (each within the scatter of the next, the first and the last beyond it).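

In this assay the change to 2-chloropyridin-3-yl in place of 3-(hydroxymethyl)phenyl on an aromatic nitrogen gives a number 15 percentage points higher from compound 2 to compound 4 (beyond the scatter) and so shows that the group at this position can shift growth inhibition beyond the scatter, if modestly. Among these compounds, earlier, only compound 2 carried such a ring, so this position had no step to read. No available evidence accounts for this step. Open, as far as these compounds go, is which part of the exchange carries the step: the ring nitrogen, the chlorine or the hydroxymethyl. From the compounds shown here alone, how a plain phenyl or a 3-(aminomethyl)phenyl would compare at this position also remains open.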